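Sulfonamide nitrogen substituent series: step to compound 3

This account rests on a few compounds, and the source may have more. Where it says the series, first, only, none or still open, it means among the compounds named here.

Of the compounds shown here, two have been measured in a functional assay with Rattus norvegicus as the target; a lower number here means that less compound is needed, a higher number that more compound is needed for the effect. Compound 1 `CC1(C)C=C(n2ccccc2=O)c2cc(S(=O)(=O)NCCO)ccc2O1` gives 1000 nM in this assay, and compound 2 `CC1(C)C=C(n2ccccc2=O)c2cc(S(=O)(=O)NCc3ccccc3)ccc2O1` gives 1320 nM. Among the compounds with values here, the only step between measured compounds, a 1.3-fold higher number from compound 1 to compound 2 (0.12 log units; within the scatter), exchanges the group on the saturated chain carbon bound to the sulfonamide nitrogen. Compound 2 therefore holds the higher of the two numbers, but its distance to compound 1 is inside the usual spread of repeats, so no order between the two can be claimed.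

Compound 3 `CC1(C)C=C(n2ccccc2=O)c2cc(S(=O)(=O)NC(=O)Nc3ccccc3)ccc2O1` is not yet measured. Its change from compound 2 is phenylcarbamoyl in place of benzyl on a sulfonamide nitrogen. Within the data shown here, the one measured step bears on it only loosely: it also alters the substituent on the sulfonamide nitrogen side and produced no shift beyond the scatter. Nothing else on this position is known. The expectation for compound 3 is therefore a step of a 1.1-fold higher number from compound 2 to compound 3 (0.06 log units; within the scatter), that is no change beyond the scatter, with a wide band to cover the new group type. Compound 3 is estimated at 1500 nM in this assay, with a range from 500 nM to 5000 nM.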

Compound 3, half-maximal effective concentration: 10000 nM
Estimate against measurement, compound 3: 6.7-fold (0.82 log units) below, outside the stated range (above it).
By their numbers in this assay, from the lowest: compounds 1 and 2 (each within the scatter of the next); then compound 3.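

The sulfonamide nitrogen position is not indifferent to its substituent in this assay: phenylcarbamoyl in place of benzyl gives a 7.6-fold higher number from compound 2 to compound 3 (0.88 log units; beyond the scatter), a step beyond the scatter where the earlier pair showed none. Phenylcarbamoyl in place of 2-hydroxyethyl gives a 10-fold higher number from compound 1 to compound 3 (1.00 log units; beyond the scatter), so the higher number appears against both earlier substituents, which themselves lie within the scatter of each other. The entering group brings one nitrogen, one oxygen and a carbonyl that benzyl lacks, but no measurement separates these features, and no supporting data bear on the origin of the shift.

Still open, going by these compounds, is whether the higher number goes with the carbonyl alone or with the whole phenylcarbamoyl group, a question that an acetyl or benzoyl group on the sulfonamide nitrogen would address directly. Within the data shown here, also open are how a longer chain, an amine or a carboxylic acid on this nitrogen would read, and whether a substituted phenyl within the phenylcarbamoyl group would bring the number back towards those of the earlier compounds.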